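One Five-Membered Ring for Another on the Shared Core

This account rests on a few compounds, and the source may have more. Where it says the series, first, only, none or still open, it means among the compounds named here.

Measured so far:
compound 1, `CC(C)C(c1nnc[nH]1)c1ccc(-c2ccc3cccc(F)c3c2)[nH]c1=O` — 0.552 h
compound 2, `CCn1ncc2c(F)cc(-c3ccc(C(CC)(CC)c4ncn(C)n4)c(=O)[nH]3)cc21` — > 3 h

In an ADME assay on microsomes from liver (Rattus norvegicus) for metabolic stability (on this read-out lower numbers stand for a shorter-lived compound and higher numbers for a longer-lived compound), compound 1 gives 0.552 h. For compound 2 this assay reports > 3 h, which is a limit of the assay rather than a number. Compound 1 therefore holds the only number shown, while the other result sits at the limit of > 3 h in this assay, at which 1 of the 2 values shown sits. Going by the values given here, compound 1 and compound 2 differ at several places at once, and no single step between them is set out; their two values show only that one is a number and the other a limit.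

Compound 3, `CC(C)C(c1noc(=O)[nH]1)c1ccc(-c2ccc3cccc(F)c3c2)[nH]c1=O`, has not yet been measured in this assay. It differs from compound 1 in one place: a group of 6 heavy atoms (2 carbon, 2 nitrogen, 2 oxygen; one five-membered aromatic ring with 3 hetero atoms) in place of a group of 5 heavy atoms (2 carbon, 3 nitrogen; one five-membered aromatic ring with 3 hetero atoms), on a saturated chain carbon bound to an aromatic carbon and a saturated chain carbon. Among the compounds with values here, no measured step of this kind is available to guide the expectation. The step of a 1.3-fold higher number from compound 1 to compound 3 (0.10 log units; within the scatter) is expected to stay within the usual scatter, with no clear direction. Compound 3 is accordingly expected to give about 0.7 h, within a range from 0.3 h to 1.8 h.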

Compound 3, half-life: > 3 h
Compound 3: only a limit was reported (the forecaster's own chance of this, stated with the estimate: 10%); at least 4.2-fold (0.63 log units) between middle value and limit.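

On the shared core, the change at this saturated chain carbon now has a measured effect: in this assay, putting the new five-membered aromatic ring in place of the 4H-1,2,4-triazol-3-yl group gives an at least 5.4-fold higher number from compound 1 to compound 3 (0.73 log units; beyond the scatter). The result for compound 3 is a limit of the assay and not a number, so only the lowest possible size of this step is known. A second compound now reads this way, and the only number shown remains that of compound 1: the limit of > 3 h in this assay, at which 2 of the 3 values shown sit.

The compounds shown leave open whether the same exchange would give a step of this kind on the differently built compound 2. They also leave open how a carboxylic acid or an amine at this same carbon would read in this assay.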